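The source may report more compounds than this note shows. Statements on the series, on what has been measured and on what is new or still open speak of the compounds shown alone.

Compound 1 `CCc1ccc(-n2nc(-c3ccc(C(F)(F)F)cc3O)nc2-c2ccccc2O)cc1` gives 57000 nM in a toxicity assay on HaCaT cells (Homo sapiens) for cytotoxicity, read by MTT assay; on this read-out higher numbers stand for weaker inhibition and lower numbers for stronger inhibition
Compound 2 `CC(C)c1ccc(-n2nc(-c3ccc(C(F)(F)F)cc3O)nc2-c2ccccc2O)cc1` gives 51400 nM in this assay
Compound 3 `Oc1cc(C(F)(F)F)ccc1-c1nc(-c2ccccc2O)n(-c2ccc(I)cc2)n1` gives 32100 nM in this assay

Compound 1 shows the highest of these three numbers, but its gaps to the others stay within the scatter. Compound 4 `Oc1cc(C(F)(F)F)ccc1-c1nc(-c2ccccc2O)n(-c2cccc(C(F)(F)F)c2)n1` has 3-(trifluoromethyl)phenyl in place of 4-ethylphenyl on an aromatic nitrogen. For the measured compounds named here, no measured compound carries this group, so the nearest guides are the other changes at this place: a 1.1-fold lower number from compound 1 to compound 2 (0.04 log units; within the scatter), a 1.8-fold lower number from compound 1 to compound 3 (0.25 log units; within the scatter) and a 1.6-fold lower number from compound 2 to compound 3 (0.20 log units; within the scatter), all small and within the scatter. No step beyond the scatter is therefore expected in this assay for the new group. The estimated step is modest (a 1.4-fold lower number from compound 1 to compound 4 (0.15 log units; within the scatter)). For compound 4 the expected value is 40000 nM, with an estimated range from 20000 nM to 80000 nM as its limits.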

Compound 4, half-maximal inhibitory concentration: 54300 nM
For compound 4 the middle estimate is 1.4-fold (0.13 log units) below the measured one, within the range that was stated.
By their numbers in this assay, from the lowest: compounds 3, 2, 4 and 1 (each within the scatter of the next).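

In this assay, swapping the group on the aromatic nitrogen for 3-(trifluoromethyl)phenyl gives steps that all stay within the scatter (a 1.0-fold lower number from compound 1 to compound 4 (0.02 log units; within the scatter)) (a 1.7-fold higher number from compound 3 to compound 4 (0.23 log units; within the scatter)) (a 1.1-fold higher number from compound 2 to compound 4 (0.02 log units; within the scatter)). Across these four compounds, this place therefore shows no measurable sensitivity, even with a fluorine-bearing group whose substituent is named at a different ring position from the other three. No evidence here explains this. From the compounds shown here alone, whether an amine or a carboxylic acid on this phenyl ring would produce a step beyond the scatter remains open.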